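Swapping a ring oxygen for a ring nitrogen in compound 3

The source may hold more compounds than are shown below. What is called first, only, known or untested is meant among the compounds shown, and "the series" means these compounds.

Within the data shown here, compound 3 `O=C(NCc1ccc(S(=O)(=O)N2CCCCC2)cc1)c1cc2cnccc2o1` gives 140 nM in an assay for inhibition of Nicotinamide phosphoribosyltransferase (Homo sapiens), read by mass spectrometry, with stated times of 15 min and 30 min (a lower number here means a stronger inhibitor, a higher number a weaker inhibitor), the second highest of the three numbers known. Compound 1 `O=C(NCc1ccc(S(=O)(=O)N2CCCCC2)cc1)c1cc2cnccc2s1` gives 150 nM, and the step of a 1.1-fold lower number from compound 1 to compound 3 (0.03 log units; within the scatter) is the only measured one. Compound 2 `O=C(NCc1ccc(S(=O)(=O)c2ccccc2C(F)(F)F)cc1)c1cc2cnccc2[nH]1` gives 24 nM, but it also carries a different sulfonyl part, so its two values with compound 3 stand alone. Compound 4 `O=C(NCc1ccc(S(=O)(=O)N2CCCCC2)cc1)c1cc2ccncc2[nH]1` differs from compound 3 by a group of 9 heavy atoms (7 carbon, 2 nitrogen; one five-membered aromatic ring with 1 hetero atom, one six-membered aromatic ring with 1 hetero atom) in place of a group of 9 heavy atoms (7 carbon, 1 nitrogen, 1 oxygen; one five-membered aromatic ring with 1 hetero atom, one six-membered aromatic ring with 1 hetero atom), on a carbonyl carbon. Among the measured compounds shown here, no measured step follows this change directly, so the expectation rests on compound 2, whose 24 nM hints that a ring bearing a hydrogen-bond donor can give a lower number. Compound 4 is therefore expected to show a step of a 2.0-fold lower number from compound 3 to compound 4 (0.30 log units; within the scatter), giving an estimated 70 nM within 20 nM to 250 nM.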

Compound 4, half-maximal inhibitory concentration: 1000 nM
Compound 4: the middle estimate sits 14-fold (1.15 log units) below what was measured; the measured number lies above the stated range.
By their numbers in this assay, from the lowest: compound 2; then compounds 3 and 1 (each within the scatter of the next); then compound 4.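

Changing only the group on the carbonyl carbon gives a 7.1-fold higher number from compound 3 to compound 4 (0.85 log units; beyond the scatter) and a 6.7-fold higher number from compound 1 to compound 4 (0.82 log units; beyond the scatter). Among these compounds, the earlier step between compound 1 and compound 3 stayed within the scatter, so these steps are the first to show that this position responds to a change of group. Here, the entering group with 1 hydrogen-bond donor goes with the weaker inhibitor, and no measurement bearing on the cause is available. On these data alone, whether that donor matters remains open, since the two groups also differ in their ring atoms. A matching group with a methyl on the five-membered ring's nitrogen would help separate these differences.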